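Anilide versus benzylamide on a shared chromone-free core

A few compounds are considered here, and "the series" means these few. Any claim that something is new, unique, unknown or untested is made for them only; others in the source may bear on it.

Two close relatives of one scaffold have been measured. Compound 1 `COc1ccc2c(=O)c(/C=C/C(=O)Nc3cc(C)ccc3C)coc2c1` carries a 2,5-dimethylphenyl group on its amide-type nitrogen, and in a functional assay on Huh-7 cells (Homo sapiens) for inhibition, read by MTT assay, with a stated time of 48 h (on this read-out higher numbers stand for weaker inhibition and lower numbers for stronger inhibition), compound 1 gives 11100 nM. Compound 2 `COc1ccc2c(=O)c(/C=C/C(=O)NCc3ccc(F)cc3)coc2c1` carries a 4-fluorobenzyl group at the same position instead, and in this assay compound 2 gives 21000 nM. Going by the values given here, the only change between them is a 1.9-fold higher number from compound 1 to compound 2 (0.28 log units; within the scatter), so on the two numbers available compound 2 sits at the higher end, but the gap to compound 1 is not one that repeated testing could reliably separate.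

Compound 3 `COc1ccc2c(=O)c(/C=C/C(=O)Nc3ccccc3OC)coc2c1` is the next variation: 2-methoxyphenyl in place of 4-fluorobenzyl on an amide-type nitrogen. Like compound 1, it places an aromatic ring directly on the nitrogen rather than through a one-carbon linker. Among the compounds with values here, the single measured step that bears on this kind of exchange, from compound 1 to compound 2, stayed within the scatter, so the return to a directly attached aromatic ring is expected to move the number little, if anything slightly toward compound 1. The estimated step is a 1.5-fold lower number from compound 2 to compound 3 (0.18 log units; within the scatter). For compound 3 the expected value in this assay is 14000 nM, with a range from 5000 nM to 40000 nM.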

Compound 3, half-maximal inhibitory concentration: 32300 nM
Estimate against measurement, compound 3: 2.3-fold (0.36 log units) below; the range from low to high includes it.
By their numbers in this assay, from the lowest: compounds 1, 2 and 3 (each within the scatter of the next, the first and the last beyond it).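

In this assay the new result separates the two compounds that both carry an aromatic ring directly on the amide-type nitrogen: 2-methoxyphenyl in place of 2,5-dimethylphenyl gives a 2.9-fold higher number from compound 1 to compound 3 (0.46 log units; beyond the scatter) and leaves compound 3 weaker than compound 1. Direct attachment of the ring therefore does not settle the number on its own, since what the ring carries can matter at this position, while the exchange of 4-fluorobenzyl for 2-methoxyphenyl gives a 1.5-fold higher number from compound 2 to compound 3 (0.19 log units; within the scatter) and leaves compound 2 inseparable from compound 3 and from compound 1. Nothing at hand explains why the two directly attached rings differ in this way.

The set also cannot show whether the gap between compound 1 and compound 3 follows the methoxy group, the methyl groups or their placement, and a plain phenyl or a 2-methylphenyl on the same nitrogen would help to divide those possibilities. Going by these compounds, how a longer chain such as 2-phenylethyl, or a ring-free group such as cyclohexyl, would behave at this position also remains open.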